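This account rests on a few compounds, and the source may have more. Where it says the series, first, only, none or still open, it means among the compounds named here.

Working notes on the series. The set shares the core of compound 1 `CCn1cc(-c2nc3ccccc3[nH]2)c(=O)c2cc(F)c(N3CCNCC3)cc21`. In a functional assay on HepG2 cells (Homo sapiens) for cytotoxicity, read by sulforhodamine B assay, with a stated time of 48 h (a lower number here means a stronger inhibitor, a higher number a weaker inhibitor), compound 1 gives only a limit, > 10000 nM, and no number. Compound 2 `CCn1cc(-c2nc3ccc(Cl)cc3[nH]2)c(=O)c2cc(F)c(N3CCNCC3)cc21` carries chloro in place of hydrogen on an aromatic carbon of that core, and in this assay compound 2 gives 3700 nM. Within the data shown here, the step of an at least 2.7-fold lower number from compound 1 to compound 2 (0.43 log units; beyond the scatter) is the only single-site step measured here, and its size is bounded by the limit of > 10000 nM in this assay, at which 1 of the 3 values shown sits, rather than fixed. Compound 3 `CCn1cc(-c2nc3ccc([N+](=O)[O-])cc3[nH]2)c(=O)c2cc(F)c(N3CCNC(C)C3)c(F)c21` differs from compound 2 at several places at once; in this assay compound 3 gives 4200 nM. Of the two numbers shown, compound 2 has the lower, but compound 3 sits within the scatter of it, so no order between them can be read; compound 1 stands apart only as a limit.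

Compound 4 `CCn1cc(-c2nc3ccc(N)cc3[nH]2)c(=O)c2cc(F)c(N3CCNCC3)cc21` differs from compound 2 by amino in place of chloro on an aromatic carbon. Among the measured compounds shown here, the step from compound 1 to compound 2 is the only one that bears on this change: there chloro entered and the number fell; here the same chloro leaves and amino, for which no step is measured, enters. The expectation is therefore a move back toward a higher number in this assay, of roughly the size seen before, with a real chance that compound 4 is reported only as a limit. The step of a 2.4-fold higher number from compound 2 to compound 4 (0.39 log units; beyond the scatter) is expected. Compound 4 is estimated at 9000 nM, between 3000 nM and 25000 nM.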

Compound 4, half-maximal inhibitory concentration: > 10000 nM
Compound 4 was reported as a limit; the forecaster's own chance of this, stated with the estimate: 40%; middle value at least 1.1-fold (0.04 log units) away from the limit.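

The step of an at least 2.7-fold higher number from compound 2 to compound 4 (0.43 log units; beyond the scatter) in this assay shows that amino does not take over what chloro does at this aromatic carbon. Until now chloro had been set only against hydrogen, and a second replacement at the same place does not keep the lower number of compound 2, so in this pair the outcome depends on which group sits there and not merely on hydrogen being replaced. Amino and hydrogen cannot be ordered, as the step between compound 1 and compound 4 cannot be read, and the step from chloro to amino is only a bound: the limit of > 10000 nM in this assay, at which 2 of the 4 values shown sit.

Going by these compounds, whether chloro is special or any halogen would serve stays open, and fluoro or bromo at this aromatic carbon on the otherwise unchanged core of compound 1 would separate those two readings, as would a methoxy group or a nitrile for groups without a halogen. Nitro appears only in compound 3, alongside other differences from the core, so its own part in that value cannot be separated from them.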